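Compound 4: ethyl for tert-butyl

A few compounds are considered here, and "the series" means these few. Any claim that something is new, unique, unknown or untested is made for them only; others in the source may bear on it.

Values so far in a functional assay (aorta) with Rattus norvegicus as the target (a lower number here means a stronger inhibitor, a higher number a weaker inhibitor), are:
- compound 1 `CC(C)(C)NCCCOc1ccc(S(=O)(=O)c2c(C(C)(C)C)cn3ccccc23)cc1` gives 443 nM
- compound 2 `CC(C)c1cn2ccccc2c1S(=O)(=O)c1ccc(OCCCN(C)C)cc1` gives 390 nM
- compound 3 `CCCCN(CCCC)CCCOc1ccc(S(=O)(=O)c2c(C(C)(C)C)cn3ccccc23)cc1` gives 51.9 nM

Compound 1 and compound 2 sit together at the high end of these numbers, within the scatter of each other. Compound 4 `CCc1cn2ccccc2c1S(=O)(=O)c1ccc(OCCCNC(C)(C)C)cc1` departs from compound 1 by ethyl in place of tert-butyl on an aromatic carbon. Among the compounds with values here, the only measured step, an 8.5-fold lower number from compound 1 to compound 3 (0.93 log units; beyond the scatter), leaves that carbon untouched, so no measured step bears directly on this change. Compound 2 390 nM also lacks tert-butyl there, yet differs in more than one place and lies within the scatter of compound 1. The expected result is a 1.3-fold lower number from compound 1 to compound 4 (0.10 log units; within the scatter), with no shift beyond the scatter expected in this assay. Compound 4 is estimated at 350 nM, with an expected range from 110 nM to 1100 nM.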

Compound 4, half-maximal inhibitory concentration: 413 nM
Compound 4: the middle estimate sits 1.2-fold (0.07 log units) below what was measured, and the stated range covers the measured number.
By their numbers in this assay, from the lowest: compound 3; then compounds 2, 4 and 1 (each within the scatter of the next).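

In this assay, within the data shown here, the step of a 1.1-fold lower number from compound 1 to compound 4 (0.03 log units; within the scatter) is the first measured change at this aromatic carbon, and it lies within the scatter. With the (tert-butyl)amino chain held fixed, tert-butyl is therefore not needed at this carbon to keep the number seen for compound 1, and ethyl serves equally well. No measurement at hand gives a reason for this.

On these data alone, whether a phenyl or cyclopropyl group, or plain hydrogen, would hold the number at this carbon remains open. So does whether ethyl would be equally tolerated alongside the dibutylamino chain of compound 3.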